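The source may hold more compounds than are shown below. What is called first, only, known or untested is meant among the compounds shown, and "the series" means these compounds.

Measured so far:

compound 1, `Cc1ccc(CS(=O)(=O)/C(=C/c2c[nH]c3ccccc23)C(=O)c2ccc(Cl)cc2)cc1`, in a functional assay on DU-145 cells (Homo sapiens) for inhibition, read by trypan blue exclusion, with a stated time of 96 h (a higher number here means a weaker inhibitor of growth, a lower number a stronger inhibitor of growth), gives 25000 nM;
compound 2, `COc1ccccc1/C=C(\C(=O)c1ccc(Cl)cc1)S(=O)(=O)Cc1ccc(C)cc1`, gives 10000 nM;
compound 3, `Cc1ccc(S/C(=C/c2c[nH]c3ccccc23)C(=O)c2ccc(Cl)cc2)cc1`, gives 10000 nM.

Compound 2 differs from compound 1 by one change, (2-methoxyphenyl in place of 1H-indol-3-yl on a double-bonded chain carbon bound to a double-bonded chain carbon), and that change made the step of a 2.5-fold lower number from compound 1 to compound 2 (0.40 log units; beyond the scatter). Compound 4, `COc1ccccc1/C=C(/Sc1ccc(C)cc1)C(=O)c1ccc(Cl)cc1`, is not yet measured; it differs from compound 3 by the same kind of change, (2-methoxyphenyl in place of 1H-indol-3-yl on a double-bonded chain carbon bound to a double-bonded chain carbon). The difference between the core of compound 1 and the core of compound 3 is not broken down here. Compound 3 and compound 2 stand level at the digits recorded, within the usual scatter.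

For the measured compounds named here, for compound 4 a step of about the same size is expected, a 2.2-fold lower number from compound 3 to compound 4 (0.35 log units; beyond the scatter), resting on the single earlier step of a 2.5-fold lower number from compound 1 to compound 2 (0.40 log units; beyond the scatter) and on the level values of compound 2 and compound 3. Compound 4 is therefore estimated at 4500 nM, most likely between 1500 nM and 13000 nM.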

Compound 4, concentration for 50% growth inhibition: 25000 nM
Estimate against measurement, compound 4: 5.6-fold (0.74 log units) below; measured number above the stated range.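

Putting 2-methoxyphenyl in place of 1H-indol-3-yl on the core of compound 3 gave a 2.5-fold higher number from compound 3 to compound 4 (0.40 log units; beyond the scatter) in this assay and thus moved the number the opposite way from the earlier step. The effect of this change therefore did not carry over from one core to the other: the same change on two cores in this assay, a 2.5-fold lower number (0.40 log units; beyond the scatter) from compound 1 to compound 2 and a 2.5-fold higher number (0.40 log units; beyond the scatter) from compound 3 to compound 4, 6.3-fold (0.80 log units) apart, beyond the scatter of two such steps. This shows that the result depends on the core in these two pairs, but it does not show why, nor how the change would behave on any further core.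

The compounds shown leave open whether other groups at this place, such as an amine or a carboxylic acid, would also act differently on the two cores.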